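Swapping a branched chain for a phenoxy group

The source may report more compounds than this note shows. Statements on the series, on what has been measured and on what is new or still open speak of the compounds shown alone.

Of the compounds shown here, three sharing one core have been tested in a physicochemical assay for solubility, with a stated time of 18 h, at pH 7.4; on this read-out lower numbers stand for lower solubility and higher numbers for higher solubility. Compound 1 `COc1cccc(CNCCCNc2ccnc3cc(-c4ccc(C(C)(C)C)cc4)ccc23)c1O` gives 32000 nM. Compound 3 `COc1cccc(CNCCCNc2ccnc3cc(CC(C)C)ccc23)c1O` gives 4200 nM. Compound 2 `CCC(CC)c1ccc2c(NCCCNCc3cc(F)ccc3OC)ccnc2c1` gives 4200 nM, level with compound 3 at the digits shown, so that the two of them sit together at the lowest point of these three numbers, while compound 1 sits well apart from both.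

Going by the values given here, only one measured step compares two compounds that differ in a single place: a 7.6-fold lower number from compound 1 to compound 3 (0.88 log units; beyond the scatter). In that step a branched chain took the place of a group built on an aromatic ring, and the solubility number fell clearly.

Compound 4 `COc1ccc(F)cc1CNCCCNc1ccnc2cc(Oc3ccccc3)ccc12` has not yet been measured. It differs from compound 2 in one place: phenoxy in place of pentan-3-yl on an aromatic carbon. This change runs in the opposite sense to the measured step, since a branched chain leaves and a group carrying an aromatic ring and an oxygen enters. Among the compounds with values here, only one step bears on it, and the groups are not the same ones, so the expectation is loose. A rise beyond the scatter is expected, with a 3.6-fold higher number from compound 2 to compound 4 (0.55 log units; beyond the scatter) in this assay. For compound 4 the estimate is 15000 nM, between 5000 nM and 45000 nM.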

Compound 4, solubility: 14500 nM
Compound 4: middle estimate off by 1.0-fold (0.01 log units), on the high side; low and high end bracket the measured number.
By their numbers in this assay, from the lowest: compounds 2 and 3 (each within the scatter of the next); then compound 4; then compound 1.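

In this assay, phenoxy in place of pentan-3-yl on this aromatic carbon gives a 3.5-fold higher number from compound 2 to compound 4 (0.54 log units; beyond the scatter), so this position affects the read-out in a second pair of compounds, one with a different substituted benzyl group on the far end of the chain. The earlier step, a 7.6-fold lower number from compound 1 to compound 3 (0.88 log units; beyond the scatter), ran the other way, from a group with an aromatic ring to a branched chain, and taken together the two steps place the higher number on the partner carrying an aromatic ring in both pairs, with neither pair going against this, although the groups differ and two pairs make only a small pattern. The steps show how far the number moves but not why, and nothing shown here accounts for the rise.

Phenoxy differs from pentan-3-yl in both its aromatic ring and its oxygen, so these compounds leave open which of the two goes with the higher number. A methoxy group would keep the oxygen without the ring, while a benzyl group would keep the ring without the oxygen, and either could help separate the two.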